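Moving the sulfur within the six-atom substituent of compound 2

A few compounds are considered here, and "the series" means these few. Any claim that something is new, unique, unknown or untested is made for them only; others in the source may bear on it.

Compound 1 `CCCCCNc1ncnc2c1ncn2[C@@H]1O[C@H](CO)[C@@H](O)[C@H]1O`: 13500 nM
Compound 2 `Cc1ccc(CSc2ncnc3c2ncn3[C@@H]2O[C@H](CO)[C@@H](O)[C@H]2O)cc1`: 457 nM

In an assay on isolated protein for binding affinity to Equilibrative nucleoside transporter 1 (Homo sapiens) (a lower number here means a stronger inhibitor, a higher number a weaker inhibitor), compound 2 stands lowest of the two numbers; the nearest is compound 1, separated by a 30-fold lower number from compound 1 to compound 2 (1.47 log units; beyond the scatter). Compound 3 `OC[C@H]1O[C@@H](n2cnc3c(CSc4ccccc4F)ncnc32)[C@H](O)[C@@H]1O` carries ((2-fluorophenyl)sulfanyl)methyl in place of (4-methylbenzyl)sulfanyl on an aromatic carbon. Within the data shown here, no measured step tests this rearrangement; the only step, a 30-fold lower number from compound 1 to compound 2 (1.47 log units; beyond the scatter), shows that changes at this position can be large. With the group's size and acceptor count kept, compound 3 is expected to give 1500 nM, between 300 nM and 8000 nM, a step of a 3.3-fold higher number from compound 2 to compound 3 (0.52 log units; beyond the scatter) that is estimated to be modest at most.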

Compound 3, half-maximal inhibitory concentration: 355 nM
Compound 3: the middle estimate sits 4.2-fold (0.63 log units) above what was measured, and the stated range covers the measured number.
By their numbers in this assay, from the lowest: compounds 3 and 2 (each within the scatter of the next); then compound 1.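

In this assay, replacing (4-methylbenzyl)sulfanyl with ((2-fluorophenyl)sulfanyl)methyl gives a 1.3-fold lower number from compound 2 to compound 3 (0.11 log units; within the scatter), so at this position the sulfur need not be bound directly to the aromatic carbon. The rearranged group also keeps a large difference from pentylamino, with a 38-fold lower number from compound 1 to compound 3 (1.58 log units; beyond the scatter). Nothing available here offers an explanation for this result.

The change moves the sulfur and replaces the 4-methyl group with a 2-fluoro group at once, so the two effects remain unseparated. As far as these compounds go, how an unsubstituted phenyl ring or an oxygen linker would read remains open.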